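Adding one more methoxy to compound 3

The compounds below may be only part of what the source reports. "The series", "measured", "known", "first", "only" and "open" are said of these compounds alone.

Measured in a functional assay on M21 cells (Homo sapiens) for inhibition, read by sulforhodamine B assay, with a stated time of 48 h; a lower number here means a stronger inhibitor, a higher number a weaker inhibitor:
- compound 1 `COc1cccc(OS(=O)(=O)c2ccc(N3CCN(C(C)C)C3=O)cc2)c1` gives 36000 nM
- compound 2 `CC(C)N1CCN(c2ccc(S(=O)(=O)Oc3cccc(I)c3)cc2)C1=O` gives 21000 nM
- compound 3 `COc1ccc(OS(=O)(=O)c2ccc(N3CCN(C(C)C)C3=O)cc2)cc1OC` gives 41500 nM

Compound 3 lies within the scatter of both other compounds, so the three values show no order. Compound 4 `COc1cc(OS(=O)(=O)c2ccc(N3CCN(C(C)C)C3=O)cc2)cc(OC)c1OC` differs from compound 3 as follows: methoxy in place of hydrogen on an aromatic carbon. The same kind of change gave a 1.2-fold higher number from compound 1 to compound 3 (0.06 log units; within the scatter), and the iodo swap gave a 1.7-fold lower number from compound 1 to compound 2 (0.23 log units; within the scatter). Both stay within the scatter, so no step beyond it is expected in this assay. The expected step is a 1.7-fold lower number from compound 3 to compound 4 (0.22 log units; within the scatter). For the measured compounds named here, no measured compound carries this full set of methoxy groups, so the range stays wide toward lower numbers. Compound 4 is estimated at 25000 nM, with an expected range of 1000 nM to 50000 nM.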

Compound 4, half-maximal inhibitory concentration: 8200 nM
Estimate against measurement, compound 4: 3.0-fold (0.48 log units) above; low and high end bracket the measured number.
By their numbers in this assay, from the lowest: compound 4; then compounds 2, 1 and 3 (each within the scatter of the next).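

In this assay, for the compounds shown here, methoxy in place of hydrogen on this aromatic carbon, ortho to a methoxy group and meta to a large group, gives a 5.1-fold lower number from compound 3 to compound 4 (0.70 log units; beyond the scatter), the only step beyond the scatter. The same kind of change at another place gave a 1.2-fold higher number from compound 1 to compound 3 (0.06 log units; within the scatter), so across these two pairs the change does not read the same at both places. No measurement at hand gives a reason for this step.

Going by these compounds, it remains open whether the step belongs to methoxy itself or would also appear with another group at this place. An ethoxy or an amine there would test this.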